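The source may hold more compounds than are shown below. What is called first, only, known or untested is meant among the compounds shown, and "the series" means these compounds.

Measured in a functional assay on A-375 cells (Homo sapiens) for antiproliferative activity, read by MTT assay, with a stated time of 72 h; on this read-out lower numbers stand for stronger inhibition and higher numbers for weaker inhibition
compound 1 `COc1ncc(-c2ccc3c(c2)N(c2ccc(C)cc2)C(=O)CO3)cc1NS(=O)(=O)c1ccc(F)cc1` gives 12900 nM
compound 2 `CC(C)N1C(=O)COc2ccc(-c3cnc(Cl)c(NS(=O)(=O)c4ccc(F)cc4)c3)cc21` gives 25500 nM
compound 3 `COc1cccc(N2C(=O)COc3ccc(-c4cnc5ccccc5c4)cc32)c1` gives 23600 nM

Compound 3 at 23600 nM lies within the scatter of both compound 1 and compound 2, so the three values form one band and no order can be read among them. The unmeasured compound 4 `O=C1COc2ccc(-c3cnc4ccccc4c3)cc2N1c1ccccc1` carries hydrogen in place of methoxy on an aromatic carbon, which turns 3-methoxyphenyl into phenyl (hydrogen in place of methoxy on an aromatic carbon). For the measured compounds named here, no measured pair differs in one place only, so the data give no direct measure of this change in this assay and the expectation has to start from compound 3 at 23600 nM alone. No shift beyond the scatter is expected, and no direction is favoured. The expected size of the change is a 1.1-fold lower number from compound 3 to compound 4 (0.03 log units; within the scatter) as estimated here. For compound 4 the estimated value is 22000 nM with an expected range from 10000 nM to 50000 nM in this assay.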

Compound 4, half-maximal inhibitory concentration: > 40000 nM
Compound 4 was reported as a limit; the forecaster's own chance of this, stated with the estimate: 10%; middle value at least 1.8-fold (0.25 log units) from the limit.
By their numbers in this assay, from the lowest: compounds 1, 3 and 2 (each within the scatter of the next). At a limit, above all of these: compound 4.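

For the compounds shown here, the first pair to differ in one place gives an at least 1.6-fold higher number from compound 3 to compound 4 (0.22 log units; that floor lies within the scatter). Replacing methoxy with hydrogen on this aromatic carbon therefore brings no lower number, although the floor alone does not place the pair beyond the scatter. In this assay, compound 4 is reported only as a limit, so the step has a floor but no measured size: the limit of > 40000 nM in this assay, at which 1 of the 4 values shown sits.

Going by these compounds alone, it remains open how a hydroxyl, a fluorine or an amine on the same aromatic carbon would read, and whether methoxy is the only group there that keeps a measurable value. Within the data shown here, it is also open whether 3-methoxyphenyl to phenyl reads the same way with a group other than the one compound 3 carries on the other side of the shared core.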